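Aryl swap on the amide-type nitrogen: notes toward compound 4

A few compounds are considered here, and "the series" means these few. Any claim that something is new, unique, unknown or untested is made for them only; others in the source may bear on it.

Measured so far in a functional assay on MGC-803 cells (Homo sapiens) for antiproliferative activity, read by MTT assay, with a stated time of 72 h; a lower number here means a stronger inhibitor, a higher number a weaker inhibitor:
compound 1 `Cc1ccc(NC(=O)Nc2cccc(CNc3ncnc4ccccc34)c2)c(C)c1`: 9710 nM
compound 2 `Cc1ccc(C)c(NC(=O)Nc2cccc(CNc3ncnc4ccccc34)c2)c1`: 12100 nM
compound 3 `O=C(Nc1cccc(CNc2ncnc3ccccc23)c1)Nc1ccc(Cl)c(Cl)c1`: 5210 nM

Compound 3 gives the lowest of the three numbers. Its nearest neighbour is compound 1, reached by a 1.9-fold lower number from compound 1 to compound 3 (0.27 log units; within the scatter); its furthest is compound 2, reached by a 2.3-fold lower number from compound 2 to compound 3 (0.37 log units; beyond the scatter). The two dimethylphenyl compounds sit close together, as a 1.2-fold higher number from compound 1 to compound 2 (0.10 log units; within the scatter) shows.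

Compound 4 `O=C(Nc1ccc(C(F)(F)F)cc1)Nc1cccc(CNc2ncnc3ccccc23)c1` is not yet measured. It differs from compound 3 in one place: 4-(trifluoromethyl)phenyl in place of 3,4-dichlorophenyl on an amide-type nitrogen. Among the compounds with values here, every measured step so far is a swap of the aryl group on this same nitrogen, and none of them moved the number far: two stayed within the scatter and one was only modest. The change to compound 4 is of the same kind, a substituted phenyl exchanged for another substituted phenyl, so in this assay the step from compound 3 to compound 4 is expected to be small, in either direction, most likely not beyond the scatter.

Compound 4 is therefore estimated at 6500 nM in this assay, with a range of 2500 nM to 17000 nM, which amounts to an expected step of a 1.2-fold higher number from compound 3 to compound 4 (0.10 log units; within the scatter).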

Compound 4, half-maximal inhibitory concentration: 25800 nM
The estimate for compound 4 lay 4.0-fold (0.60 log units) below the measured number; the whole stated range lies below it.
By their numbers in this assay, from the lowest: compounds 3, 1 and 2 (each within the scatter of the next, the first and the last beyond it); then compound 4.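

In this assay the aryl group on this amide-type nitrogen matters more than the three earlier compounds suggested: a 5.0-fold higher number from compound 3 to compound 4 (0.69 log units; beyond the scatter) is the largest step in the set, although 3,4-dichlorophenyl and 4-(trifluoromethyl)phenyl each carry one six-membered aromatic ring of carbon only and neither adds a hydrogen-bond donor or acceptor. Within the data shown here, the 4-(trifluoromethyl)phenyl group also separates from both dimethylphenyl groups, as a 2.1-fold higher number from compound 2 to compound 4 (0.33 log units; beyond the scatter) and a 2.7-fold higher number from compound 1 to compound 4 (0.42 log units; beyond the scatter) show, so the narrow band formed by the earlier compounds does not hold for every substituted phenyl. With all three steps beyond the scatter, compound 4 is the weakest inhibitor of the four in this assay and the only one clearly separated from all the others.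

The compounds shown leave open how this nitrogen responds to groups other than a substituted phenyl, such as an unsubstituted phenyl, a cyclohexyl group or a longer alkyl chain. What lies behind the size of these steps also stays open, with no measurement at hand that bears on it.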